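Compound 2 to compound 3: methoxy for methyl

The source may report more compounds than this note shows. Statements on the series, on what has been measured and on what is new or still open speak of the compounds shown alone.

In a functional assay on A549 cells (Homo sapiens) for cytotoxicity, read by MTT assay, with a stated time of 72 h (on this read-out higher numbers stand for weaker inhibition and lower numbers for stronger inhibition), compound 2 `Cc1ccc(S(=O)(=O)c2nc3ccccc3nc2N2CCCC(O)C2)cc1` gives 1350 nM, the only number shown so far. Compound 1 `COc1ccc(S(=O)(=O)c2nc3ccccc3nc2N2CCc3ccccc3C2)cc1` reaches only a limit in this assay (> 50000 nM). Compound 3 `COc1ccc(S(=O)(=O)c2nc3ccccc3nc2N2CCCC(O)C2)cc1` carries methoxy in place of methyl on an aromatic carbon, para to a large group (methoxy in place of methyl on an aromatic carbon). Within the data shown here, no measured step covers this change, so the expectation in this assay is for no shift beyond the scatter and no firm direction. The expected step is small (a 1.1-fold higher number from compound 2 to compound 3 (0.05 log units; within the scatter)). For compound 3 the estimated value is 1500 nM (expected range 600 nM to 4500 nM).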

Compound 3, half-maximal inhibitory concentration: 2180 nM
The estimate for compound 3 lay 1.5-fold (0.16 log units) below the measured number; low and high end bracket the measured number.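

In this assay, among these compounds, the first measured change at this position, 4-methylphenyl to 4-methoxyphenyl with 3-hydroxypiperidin-1-yl held constant, gives a 1.6-fold higher number from compound 2 to compound 3 (0.21 log units; within the scatter). With 4-methoxyphenyl held constant, 3-hydroxypiperidin-1-yl in place of 1,2,3,4-tetrahydroisoquinolin-2-yl gives an at least 22-fold lower number from compound 1 to compound 3 (1.36 log units; beyond the scatter), a far larger step than the one at the aromatic carbon. The figure for compound 1 is a limit, not a number: the limit of > 50000 nM in this assay, at which 1 of the 3 values shown sits.

As far as these compounds go, whether a chlorine, an amine or a carboxylic acid in place of methoxy would stay within the scatter remains open. From the compounds shown here alone, the contribution of the hydroxy group on the piperidine also remains open.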